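This account rests on a few compounds, and the source may have more. Where it says the series, first, only, none or still open, it means among the compounds named here.

Measured so far:
compound 1, `COc1ccccc1CCCNC(C)=O`, 1430 nM
compound 2, `CCC(=O)NCCCc1ccccc1OC`, 374 nM
compound 3, `CCCC(=O)NCCCCc1ccccc1OC`, 116 nM

All three were tested in an assay for binding affinity to melatonin receptor (Gallus gallus); a higher number here means a weaker inhibitor, a lower number a stronger inhibitor. Compound 1 and compound 2 differ in one place: methyl in place of hydrogen on a saturated chain carbon bound to a carbonyl carbon. That single change gave a 3.8-fold lower number from compound 1 to compound 2 (0.58 log units; beyond the scatter). Compound 3 shares the same kind of skeleton but differs from compound 1 in more than one place, so the difference between the two cores is not broken down here; what the values show is that compound 3 gives the lowest number of the three, beyond the usual scatter in both comparisons.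

Compound 4, `CCCCC(=O)NCCCCc1ccccc1OC`, has not yet been measured. It differs from compound 3 in one place: methyl in place of hydrogen on a saturated chain carbon, three bonds along the chain from a carbonyl carbon. Going by the values given here, this is the same kind of change as the one from compound 1 to compound 2, but not the same change: there the added methyl sat on a saturated chain carbon bound to a carbonyl carbon, here it sits on a saturated chain carbon three bonds along the chain from a carbonyl carbon, so the chain on the carbonyl side grows by one carbon further out.

Because the earlier lengthening gave a 3.8-fold lower number from compound 1 to compound 2 (0.58 log units; beyond the scatter), a further step in the same direction is expected to help again, though probably less, and the step from compound 3 to compound 4 is estimated at a 1.5-fold lower number from compound 3 to compound 4 (0.19 log units; within the scatter). Compound 4 is therefore expected to come in at about 75 nM, with a plausible range from 25 nM to 250 nM.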

Compound 4, inhibition constant: 9190 nM
Estimate against measurement, compound 4: 120-fold (2.09 log units) below; the measured number lies above the stated range.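

In this assay, going by these compounds alone, lengthening the chain on the carbonyl side from propyl to butyl gave a 79-fold higher number from compound 3 to compound 4 (1.90 log units; beyond the scatter), so a single added methyl was enough to turn the lowest number so far into the highest of the four. A change of this kind therefore cannot be carried from one core to another in this series with its size or even its direction intact, as the two steps side by side show: the same change on two cores in this assay, a 3.8-fold lower number (0.58 log units; beyond the scatter) from compound 1 to compound 2 and a 79-fold higher number (1.90 log units; beyond the scatter) from compound 3 to compound 4, 300-fold (2.48 log units) apart, beyond the scatter of two such steps What this does not show is the reason for the reversal, since the two steps differ both in the core and in the place of the added methyl, on a saturated chain carbon bound to a carbonyl carbon in one case and three bonds along the chain from a carbonyl carbon in the other, and two pairs of compounds cannot separate those two differences.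

The compounds shown leave open whether the number stays high with a longer chain on the carbonyl side, or whether a branched chain or a ring of the same size there behaves like the butyl group. They also leave open how the butyl group would behave on the core of compound 1, which would show whether the core or the chain itself decides the outcome.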